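This account rests on a few compounds, and the source may have more. Where it says the series, first, only, none or still open, it means among the compounds named here.

Measured compounds:

compound 1, `Cc1ccc(C)c(-c2nc(CN3CCC(C(=O)NCCCN4C[C@H](C)C[C@H](C)C4)CC3)c(C)o2)c1`: "not determined" (no result reported)
compound 2, `Cc1cc(C)c(-c2nc(CN3CCC(C(=O)NCCCN4C[C@H](C)C[C@H](C)C4)CC3)c(C)o2)c(C)c1`: "not determined" (no result reported)
compound 3, `Cc1ccccc1-c1nc(CN2CCC(C(=O)NCCCN3CC(C)(C)CC(C)(C)C3)CC2)c(C)o1`: > 1390 10^-6 cm/s

The account follows the step from compound 1 to compound 4, `Cc1oc(-c2ccccc2Cl)nc1CN1CCC(C(=O)NCCCN2C[C@H](C)C[C@H](C)C2)CC1`, in a physicochemical assay for permeability, using PAMPA; a lower number here means that the compound crosses the layer more slowly, a higher number that the compound crosses the layer faster. Compound 1 stands on no number in this assay; the entry for compound 1 is "not determined" (no result reported), and the entry for compound 2 is likewise "not determined" (no result reported). Among the compounds with values here, compound 3 is the only compound of the three with a reported value, and that value is a limit of the assay rather than a number: in this assay compound 3 gives > 1390 10^-6 cm/s. Within the data shown here, this is the one piece of evidence available, (the limit of > 1390 10^-6 cm/s in this assay, at which 1 of the 3 values shown sits).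

The change from compound 1 to compound 4 is 2-chlorophenyl in place of 2,5-dimethylphenyl on an aromatic carbon of the shared core. Among the measured compounds shown here, no step between two measured compounds exists in this assay, so no measured size or direction can be borrowed. Given that the single reported entry, for compound 3, is > 1390 10^-6 cm/s, the expectation is a step of no particular direction and of no size beyond the scatter, with the result quite possibly again reported as a limit.

Compound 4 is therefore expected to give about 1200 10^-6 cm/s in this assay, within a range from 400 10^-6 cm/s to 2500 10^-6 cm/s.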

Compound 4, apparent permeability: 352 10^-6 cm/s
Estimate against measurement, compound 4: 3.4-fold (0.53 log units) above; the whole stated range lies above it.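

In this assay, within the data shown here, compound 4 gives 352 10^-6 cm/s, while compound 1 has no single number to set against it, so no step from compound 1 to compound 4 can be read. The compounds shown leave open what replacing 2,5-dimethylphenyl with 2-chlorophenyl on the shared core does to the read-out in this assay.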